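Swapping the fluorinated aniline ring for a trifluoromethyl one

The compounds below may be only part of what the source reports. "The series", "measured", "known", "first", "only" and "open" are said of these compounds alone.

Measured so far:
Compound 1, `COc1cc2ncnc(Nc3ccc(F)cc3)c2cc1OCCCCC(=O)Nc1ccc(S(N)(=O)=O)cc1`, gives 18600 nM in a functional assay on A-431 cells (Homo sapiens) for antiproliferative activity, read by MTT assay, with a stated time of 72 h; a higher number here means a weaker inhibitor, a lower number a stronger inhibitor.
Compound 2, `COc1cc2ncnc(Nc3cc(F)c(F)c(F)c3)c2cc1OCCCCC(=O)Nc1ccc(S(N)(=O)=O)cc1`, gives 23400 nM in this assay.

Both numbers sit in the same weak region. Compound 2 stands at one end of this pair, yet the difference to compound 1, a 1.3-fold higher number from compound 1 to compound 2 (0.10 log units; within the scatter), is within the scatter, so the two compounds cannot be told apart on these numbers.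

Compound 3, `COc1cc2ncnc(Nc3ccc(C(F)(F)F)cc3)c2cc1OCCCCC(=O)Nc1ccc(S(N)(=O)=O)cc1`, is not yet measured. It differs from compound 2 by 4-(trifluoromethyl)phenyl in place of 3,4,5-trifluorophenyl on a nitrogen on an aromatic ring.

Going by the values given here, no measured step matches this exact change. Among the compounds with values here, the only step available, from compound 1 to compound 2, altered the fluorine pattern on the same ring and gave a 1.3-fold higher number from compound 1 to compound 2 (0.10 log units; within the scatter), a step within the scatter. The shared core, the linker and the sulfonamide-bearing ring are untouched. On this slim evidence the expectation for compound 3 is no step beyond the scatter, a 1.1-fold lower number from compound 2 to compound 3 (0.05 log units; within the scatter), in this assay. Compound 3 is therefore estimated at 21000 nM, with a plausible range from 8000 nM to 55000 nM.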

Compound 3, half-maximal inhibitory concentration: 16900 nM
Beside the measured number, compound 3's estimate is 1.2-fold (0.09 log units) above it; low and high end bracket the measured number.
By their numbers in this assay, from the lowest: compounds 3, 1 and 2 (each within the scatter of the next).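

Replacing 3,4,5-trifluorophenyl with 4-(trifluoromethyl)phenyl on the nitrogen gives a 1.4-fold lower number from compound 2 to compound 3 (0.14 log units; within the scatter) in this assay, and trifluoromethyl in place of fluoro on an aromatic carbon gives a 1.1-fold lower number from compound 1 to compound 3 (0.04 log units; within the scatter), so neither step can be told apart from repeated-measurement noise. Going by these compounds alone, the earlier pair showed only that the number of fluorine substituents on the ring could differ without a readable step; this result extends that to a different group, one with 10 heavy atoms against 9, in which the fluorines sit on a carbon outside the ring, and the three compounds remain indistinguishable in this assay. Nothing at hand offers a reason for this flat picture.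

The compounds shown leave open whether a plain phenyl ring, or a ring carrying an amine or a carboxylic acid, would move the number beyond the scatter at this position. Going by these compounds, it also remains open whether a shorter or longer chain between the shared core and the sulfonamide-bearing ring would have a larger effect than any change on this ring.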